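Benzyloxy variation on the acylthiourea and acylurea benzimidazole series

The source may hold more compounds than are shown below. What is called first, only, known or untested is meant among the compounds shown, and "the series" means these compounds.

Compound 3 `Cc1ccc(NC(=O)NC(=O)c2ccc(OCc3ccc(C(F)(F)F)cc3)cc2)cc1-c1nc2ccccc2[nH]1` carries an acylurea link and a 4-(trifluoromethyl)benzyl ether; in a functional assay on MNK45 cells (Homo sapiens) for inhibition, read by MTT assay, with a stated time of 48 h (on this read-out lower numbers stand for stronger inhibition and higher numbers for weaker inhibition), compound 3 gives 16800 nM. Among the three measured compounds this number lies above that of compound 1 `Cc1ccc(NC(=S)NC(=O)c2ccc(OCc3cccc(Cl)c3)cc2)cc1-c1nc2ccccc2[nH]1` beyond the scatter, compound 1 giving 43300 nM, and within the scatter of compound 2 `Cc1ccc(NC(=S)NC(=O)c2ccc(OCc3ccc(Cl)c(Cl)c3)cc2)cc1-c1nc2ccccc2[nH]1`, compound 2 giving 8410 nM. Compound 4 `Cc1ccc(NC(=O)NC(=O)c2ccc(OCc3cccc(F)c3)cc2)cc1-c1nc2ccccc2[nH]1` differs from compound 3 by 3-fluorophenyl in place of 4-(trifluoromethyl)phenyl on a saturated chain carbon bound to an oxygen on an aromatic ring. Among the compounds with values here, the only measured step, a 5.1-fold lower number from compound 1 to compound 2 (0.71 log units; beyond the scatter), concerns a chloro added on the acylthiourea pair and does not touch this exchange, so no direct guide exists. Compound 4 is expected near compound 3, with a 1.5-fold higher number from compound 3 to compound 4 (0.17 log units; within the scatter) leaning toward a weaker number, estimated at 25000 nM within 8000 nM to 75000 nM.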

Compound 4, half-maximal inhibitory concentration: 53000 nM
For compound 4 the middle estimate is 2.1-fold (0.33 log units) below the measured one; the measured number falls inside the stated range.
By their numbers in this assay, from the lowest: compounds 2 and 3 (each within the scatter of the next); then compounds 1 and 4 (each within the scatter of the next).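

With the acylurea link held, 3-fluorophenyl in place of 4-(trifluoromethyl)phenyl on a saturated chain carbon bound to an oxygen on an aromatic ring gives a 3.2-fold higher number from compound 3 to compound 4 (0.50 log units; beyond the scatter) in this assay and so shows that the number responds to the aryl group on the acylurea pair, which the chloro step on the acylthiourea pair could not show. No measured evidence bears on the origin of this step. The compounds shown leave open whether the group itself or its place on the ring carries the step, and whether the exchange reads alike on the acylthiourea link. From the compounds shown here alone, how an amine or a carboxylic acid on that phenyl ring would read also stays open.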